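Toward compound 3: a pyrrolidinylpropyl replaces the diaminobutyl chain

The compounds below may be only part of what the source reports. "The series", "measured", "known", "first", "only" and "open" are said of these compounds alone.

Compound 2 `CCCCCCCCCCc1ccc(-c2noc([C@@H](N)CCCN)n2)cc1` gives 40% in an assay on HeLa cells for inhibition of sphingosine-1-phosphate transporter SPNS2 (Mus musculus), read by LC-MS, tested at 2 uM (on this read-out lower numbers stand for less inhibition and higher numbers for more inhibition at the one concentration tested (going by the name of the read-out)), and stands highest of the two numbers measured; its nearest neighbour, compound 1 `CCCCCCCCCCc1ccc(-c2noc([C@H]3CCC[C@@H](N)C3)n2)cc1`, gives 29% in this assay. Within the data shown here, the one measured step, a number 11 percentage points higher from compound 1 to compound 2 (beyond the scatter), is the only comparison available for what a change of the amine-bearing group on the shared core does. Compound 3 `CCCCCCCCCCc1ccc(-c2noc(CCCN3CCCC3)n2)cc1` differs from compound 2 by 3-(pyrrolidin-1-yl)propyl in place of 1,4-diaminobutyl on an aromatic carbon. Among the measured compounds shown here, no measured step covers this kind of exchange, in which both hydrogen-bond donors and the defined stereocentre leave and a five-membered ring enters. For the measured compounds named here, since the only step seen is modest, compound 3 is expected to show a number 10 percentage points lower from compound 2 to compound 3 (within the scatter), a modest fall. Compound 3 is therefore estimated at 30% in this assay, within a range from 10% to 50%.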

Compound 3, a percentage reported as inhibition, at one concentration (the size of the read-out at that concentration, not a potency): 3%
Compound 3: the middle estimate sits 27 percentage points above what was measured, outside the stated range (below it).
By their numbers in this assay, from the lowest: compound 3; then compound 1; then compound 2.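

In this assay, the exchange of 1,4-diaminobutyl for 3-(pyrrolidin-1-yl)propyl on this aromatic carbon gives a number 37 percentage points lower from compound 2 to compound 3 (beyond the scatter), so the position can lose nearly all of the read-out, a far larger shift than the earlier pair revealed. The exchange of 3-aminocyclohexyl for the same group gives a number 26 percentage points lower from compound 1 to compound 3 (beyond the scatter), which places both earlier amine-bearing groups above the pyrrolidinylpropyl group, whether cyclic or open-chain. Nothing available explains this fall.

The exchange removes the hydrogen-bond donors and the defined stereocentre and brings in a five-membered ring all at once, and the compounds shown cannot separate these changes. An open-chain dimethylaminopropyl group or a simple aminopropyl chain at this position would bear on which of them goes with the lower number.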